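The source may report more compounds than this note shows. Statements on the series, on what has been measured and on what is new or still open speak of the compounds shown alone.

Of the compounds shown here, three of one shared core have been measured in a functional assay on PC-3 cells (Homo sapiens) for cytotoxicity, read by MTT assay, with a stated time of 24 h; on this read-out lower numbers stand for stronger inhibition and higher numbers for weaker inhibition. Compound 1 `COc1ccc(/C=C2\CN(C(=S)SCc3cn(Cc4ccccc4Cl)nn3)C/C(=C\c3ccc(OC)cc3)C2=O)cc1` gives 60100 nM. Compound 3 `COc1ccc(/C=C2\CN(C(=S)SCc3cn(Cc4ccc(F)cc4)nn3)C/C(=C\c3ccc(OC)cc3)C2=O)cc1` gives 45600 nM. For compound 2 `Cc1ccc(/C=C2\CN(C(=S)SCc3cn(Cc4ccccc4F)nn3)C/C(=C\c3ccc(C)cc3)C2=O)cc1` the result is a limit of the assay rather than a number, > 80000 nM. Of the two numbers shown, compound 3 holds the lower one, though the step of a 1.3-fold lower number from compound 1 to compound 3 (0.12 log units; within the scatter) is within the scatter, so the two cannot be told apart on this read-out.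

Compound 4 `COc1ccc(/C=C2\CN(C(=S)SCc3cn(Cc4cccc(Cl)c4)nn3)C/C(=C\c3ccc(OC)cc3)C2=O)cc1` has not yet been measured. It differs from compound 3 in one place: 3-chlorophenyl in place of 4-fluorophenyl on a saturated chain carbon bound to an aromatic nitrogen. For the measured compounds named here, the only measured step that bears on this kind of change is the one from compound 1 to compound 3, where a different halogen-bearing phenyl entered at the same place and the number moved only a 1.3-fold lower number from compound 1 to compound 3 (0.12 log units; within the scatter), within the scatter. On that basis no step beyond the scatter is expected in this assay, in either direction; the expected step of a 1.1-fold higher number from compound 3 to compound 4 (0.02 log units; within the scatter) is small. Compound 4 is therefore estimated at 48000 nM, within a range from 24000 nM to 96000 nM, with some chance that only a limit such as the limit of > 80000 nM in this assay, at which 1 of the 3 values shown sits, is reported.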

Compound 4, half-maximal inhibitory concentration: > 80000 nM
Compound 4 ended at the assay's limit; the forecaster's own chance of this, stated with the estimate: 25%; middle value at least 1.6-fold (0.22 log units) from the limit.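

In this assay, compound 4 returns a limit of the assay rather than a number, so this position is no longer seen only through a swap that stays within the scatter. Its steps are only floors, an at least 1.7-fold higher number from compound 3 to compound 4 (0.24 log units; that floor lies within the scatter) and an at least 1.3-fold higher number from compound 1 to compound 4 (0.12 log units; that floor lies within the scatter), so the true gap may be small or large, and neither floor alone shows a real loss on going to 3-chlorobenzyl. Not every compound now gives a number to compare: the limit of > 80000 nM in this assay, at which 2 of the 4 values shown sit.

The compounds shown leave open how far compound 4 really lies from compound 3, and whether the kind of halogen or its place on the ring matters more, as both differ between 4-fluorobenzyl and 3-chlorobenzyl. A 4-chlorobenzyl group on the same core would separate the two, while an amine on that ring remains an open question.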